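Hydroxy added to the methyl ester side chain of compound 2

The source may report more compounds than this note shows. Statements on the series, on what has been measured and on what is new or still open speak of the compounds shown alone.

Compound 2 `COC(=O)[C@@H](C)NC(=O)Cn1cc(C2=C(c3c[nH]c4ccccc34)C(=O)N(C)C2=O)c2ccccc21` is the reference point for this step. In a functional assay on BGC-823 cells (Homo sapiens) for cytotoxicity, read by MTT assay, with a stated time of 24 h (a higher number here means a weaker inhibitor, a lower number a stronger inhibitor), compound 2 gives 60400 nM, the highest of the three numbers recorded. Compound 3 `COC(=O)[C@H](NC(=O)Cn1cc(C2=C(c3c[nH]c4ccccc34)C(=O)N(C)C2=O)c2ccccc21)C(C)C` gives 48200 nM in this assay, and the pair is a 1.3-fold lower number from compound 2 to compound 3 (0.10 log units; within the scatter), so the two cannot be told apart. Compound 1 `COC(=O)[C@H](NC(=O)Cn1cc(C2=C(c3c[nH]c4ccccc34)C(=O)N(C)C2=O)c2ccccc21)[C@@H](C)O` gives 23300 nM and is the strongest inhibitor of the three: the step to compound 2 is a 2.6-fold higher number from compound 1 to compound 2 (0.41 log units; beyond the scatter), and the step to compound 3 is a 2.1-fold higher number from compound 1 to compound 3 (0.32 log units; beyond the scatter), both beyond the scatter.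

Compound 4 `COC(=O)[C@@H](CO)NC(=O)Cn1cc(C2=C(c3c[nH]c4ccccc34)C(=O)N(C)C2=O)c2ccccc21` is the next compound in line. It differs from compound 2 as follows: hydroxy in place of hydrogen on a saturated chain carbon, two bonds along the chain from an amide-type nitrogen and a carbonyl carbon. Among the measured compounds shown here, the steps that bear on this change are those leaving compound 1, where the 1-hydroxyethyl group carries a hydroxy that is absent in compound 2 and compound 3; removing it gave modest rises in the number. A hydroxy entering on the chain of compound 2 is therefore expected to lower the number by a modest amount, a 2.0-fold lower number from compound 2 to compound 4 (0.30 log units; within the scatter). The estimate for compound 4 in this assay is 30000 nM, with a range from 15000 nM to 60000 nM.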

Compound 4, half-maximal inhibitory concentration: 28900 nM
Estimate against measurement, compound 4: 1.0-fold (0.02 log units) above; low and high end bracket the measured number.
By their numbers in this assay, from the lowest: compounds 1, 4, 3 and 2 (each within the scatter of the next, the first and the last beyond it).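

Among the compounds shown here, with hydroxy in place of hydrogen on a saturated chain carbon, two bonds along the chain from an amide-type nitrogen and a carbonyl carbon, this assay gives a 2.1-fold lower number from compound 2 to compound 4 (0.32 log units; beyond the scatter) and so shows this single change directly, where the earlier compounds offered only the 1-hydroxyethyl group of compound 1 as a guide. The methyl that sets the 1-hydroxyethyl group apart from hydroxymethyl is not resolved by this assay, with a 1.2-fold higher number from compound 1 to compound 4 (0.09 log units; within the scatter) and thus no separation of the two hydroxy-bearing chains, while a 1.7-fold lower number from compound 3 to compound 4 (0.22 log units; within the scatter) leaves hydroxymethyl and isopropyl likewise unseparated, so compound 3 stops the hydroxy compounds from forming a clear group of their own. Nothing available explains the step from compound 2.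

The compounds shown leave open whether an amine, a methoxy group or a carboxylic acid in place of the hydroxy on this chain carbon would give a step of similar size. They also leave open how a longer chain, such as 2-hydroxyethyl, would compare with hydroxymethyl at this position.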